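Swapping the Acid-Bearing Chain on a Shared Core

This account rests on a few compounds, and the source may have more. Where it says the series, first, only, none or still open, it means among the compounds named here.

Measured so far:
compound 1: `O=C(O)CCC/C=C\CC1=CCC[C@@H]1NS(=O)(=O)c1ccccc1`, 2300 nM
compound 2: `O=C(O)COCCCCC1=CCC[C@@H]1NS(=O)(=O)c1ccccc1[N+](=O)[O-]`, 1900 nM

Both numbers come from a functional assay on a cell-free system (plasma) for inhibition of thromboxane A2 receptor (Homo sapiens), read by turbidimetry; on this read-out lower numbers stand for stronger inhibition and higher numbers for weaker inhibition. Compound 2 has the lower of the two numbers, yet its gap to compound 1 lies within the usual scatter, so the two cannot be told apart. Compound 3, `O=C(O)CCC/C=C\CC1=CCC[C@@H]1NS(=O)(=O)c1ccccc1[N+](=O)[O-]`, keeps the core of compound 2 and changes its chain: 5-carboxypent-1-en-1-yl in place of 3-(carboxymethoxy)propyl on a saturated chain carbon bound to a double-bonded ring carbon. The same chain is carried by compound 1, whose number sits beside that of compound 2. With no step beyond the scatter between the two measured compounds, no step beyond the scatter is expected from compound 2 to compound 3, that is a 1.1-fold higher number from compound 2 to compound 3 (0.02 log units; within the scatter). Compound 3 is therefore estimated at 2000 nM, within 700 nM to 6000 nM.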

Compound 3, half-maximal inhibitory concentration: 680 nM
For compound 3 the middle estimate is 2.9-fold (0.47 log units) above the measured one, outside the stated range (below it).
By their numbers in this assay, from the lowest: compound 3; then compounds 2 and 1 (each within the scatter of the next).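

Compounds 1 and 2 differ in two places, so their similar values hid the effect of each change. With the nitro group held constant, 5-carboxypent-1-en-1-yl in place of 3-(carboxymethoxy)propyl gives a 2.8-fold lower number from compound 2 to compound 3 (0.45 log units; beyond the scatter) in this assay and so counts at this position. With the chain held constant, nitro in place of hydrogen gives a 3.4-fold lower number from compound 1 to compound 3 (0.53 log units; beyond the scatter) and counts as well, though nothing available explains either step. Still open, from the compounds shown here alone, is whether a chlorine or a methoxy group could replace the nitro group with a similar step. Also open, going by these compounds, is whether a longer chain would lower the number further.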